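From chloro to methoxy on the aromatic ring

A few compounds are considered here, and "the series" means these few. Any claim that something is new, unique, unknown or untested is made for them only; others in the source may bear on it.

Among the measured compounds shown here, in an ADME assay on HepG2 cells (Homo sapiens) for cytotoxicity, read by MTT assay, with a stated time of 72 h (a higher number here means that more compound is tolerated, a lower number that less compound is tolerated), compound 2 (`CC(C)Nc1nc2c(-c3ccc(Cl)cc3)csc2c(=O)[nH]1`) gives 7100 nM against compound 1 (`Cc1ccc(-c2csc3c(=O)[nH]c(NC(C)C)nc23)cc1`) at 8800 nM as the only other measured number, so the two stand within the scatter of each other and cannot be ranked. The next change leads to compound 3 (`COc1ccc(-c2csc3c(=O)[nH]c(NC(C)C)nc23)cc1`) and puts methoxy in place of chloro on an aromatic carbon, para to a large group (methoxy in place of chloro on an aromatic carbon). For the measured compounds named here, one measured step bears on it: chloro in place of methyl on an aromatic carbon gave (a 1.2-fold lower number from compound 1 to compound 2 (0.09 log units; within the scatter)) and stayed within the scatter. Methoxy itself has not been measured in this series, and that single step offers no ground for a shift beyond the scatter in this assay here. The estimated change is (a 1.1-fold higher number from compound 2 to compound 3 (0.05 log units; within the scatter)) and is expected to stay within the scatter. Compound 3 is expected at 8000 nM within a range of 4500 nM to 14000 nM as the estimate.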

Compound 3, half-maximal cytotoxic concentration: 27800 nM
For compound 3 the middle estimate is 3.5-fold (0.54 log units) below the measured one; the whole stated range lies below it.
By their numbers in this assay, from the lowest: compounds 2 and 1 (each within the scatter of the next); then compound 3.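

Among the compounds shown here, on the aromatic carbon para to a large group, methoxy is the first change that moves the number in this assay beyond the scatter (a 3.9-fold higher number from compound 2 to compound 3 (0.59 log units; beyond the scatter); a 3.2-fold higher number from compound 1 to compound 3 (0.50 log units; beyond the scatter)). The earlier exchange of methyl for chloro stayed within the scatter (a 1.2-fold lower number from compound 1 to compound 2 (0.09 log units; within the scatter)), so that step alone gave no sign that this position could respond at all. The position is therefore not indifferent to its group, with both methoxy steps modest and pointing to more compound tolerated, but nothing available accounts for the shift.

Open, on these data alone, is whether ethoxy or hydroxy at the same place would raise the number further or bring it back towards compound 1 and compound 2. Also open, as far as these compounds go, is whether the methoxy step would hold with a different amine on the shared core.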